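Trifluoromethylphenyl for formylphenyl: outlook for compound 3

The compounds below may be only part of what the source reports. "The series", "measured", "known", "first", "only" and "open" are said of these compounds alone.

Measured so far:
compound 1 `O=Cc1ccc(-c2cn3ccnc3c(-c3ccc4ncn(C5CCCCC5)c4c3)n2)cc1`: 82.2%
compound 2 `COc1ccccc1-c1cn2ccnc2c(-c2ccc3ncn(C4CCCCC4)c3c2)n1`: 24%

In a functional assay on UO-31 cells (Homo sapiens) for inhibition, read by sulforhodamine B assay, with a stated time of 48 h, tested at 10 uM (a lower number here means less inhibition, a higher number more inhibition at the concentration tested (going by the name of the read-out)), compound 1 gives 82.2%, the highest of the two numbers. Its nearest neighbour is compound 2, which gives 24%; the step of a number 58.2 percentage points lower from compound 1 to compound 2 (beyond the scatter) is large and beyond the scatter. Compound 3 `FC(F)(F)c1cccc(-c2cn3ccnc3c(-c3ccc4ncn(C5CCCCC5)c4c3)n2)c1` is the next entry. Its change from compound 1: 3-(trifluoromethyl)phenyl in place of 4-formylphenyl on an aromatic carbon. For the measured compounds named here, only one measured step bears on this change, a number 58.2 percentage points lower from compound 1 to compound 2 (beyond the scatter), where the 4-formylphenyl also left the same aromatic carbon; that step was large and downward. With a single step of this kind in the series, the size of the step for the new group cannot be narrowed much, but its direction is taken from that precedent. The expected step is downward and beyond the scatter: a number 42.2 percentage points lower from compound 1 to compound 3 (beyond the scatter). Compound 3 is estimated at 40%, with a range from 10% to 75%.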

Compound 3, a percentage reported as inhibition, at one concentration (the size of the read-out at that concentration, not a potency): 22.5%
Compound 3: the middle estimate sits 17.5 percentage points above what was measured, and the stated range covers the measured number.
By their numbers in this assay, from the lowest: compounds 3 and 2 (each within the scatter of the next); then compound 1.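

In this assay, a second replacement of the 4-formylphenyl on this aromatic carbon also brings a large fall (a number 59.7 percentage points lower from compound 1 to compound 3 (beyond the scatter)), so the drop seen with compound 2 is not confined to the 2-methoxyphenyl. The exchange of 2-methoxyphenyl for 3-(trifluoromethyl)phenyl leaves the two compounds within the scatter (a number 1.5 percentage points lower from compound 2 to compound 3 (within the scatter)), and of the three compounds only compound 1, with the 4-formylphenyl, gives a high number. No measurement at hand accounts for this difference.

As far as these compounds go, whether the high number depends on the formyl group or on its place on the phenyl ring stays open, as compound 2 and compound 3 differ from compound 1 in both. A carboxylic acid, a nitrile or an aminomethyl group on that phenyl ring would bear on this question.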